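Inverting one stereocentre of the nitrile compound

This account rests on a few compounds, and the source may have more. Where it says the series, first, only, none or still open, it means among the compounds named here.

In a functional assay on MCF7 cells (Homo sapiens) for antiproliferative activity, read by MTT assay, with stated times of 24 h and 72 h (a lower number here means a stronger inhibitor, a higher number a weaker inhibitor), compound 1 `COc1ccc([C@@H]2[C@@H](Oc3ccccc3)C(=O)N2c2cc(OC)c(OC)c(OC)c2)cc1` gives 6900 nM as its read-out, while compound 2 `COc1cc(N2C(=O)[C@@H](Oc3ccccc3)[C@H]2c2ccc(C#N)cc2)cc(OC)c1OC` gives 31600 nM as its read-out. That makes compound 2 the higher of the two numbers, with the gap beyond the scatter. Going by the values given here, compound 3 `COc1cc(N2C(=O)[C@H](Oc3ccccc3)[C@H]2c2ccc(C#N)cc2)cc(OC)c1OC` is set against compound 2 through the two compounds have the same atoms and bonds and differ only in configuration as drawn: 1 of 2 stereo elements differ; a stereocentre at a saturated ring carbon is drawn S in compound 2 and R in compound 3 as the only change: a stereocentre at a saturated ring carbon is drawn S in compound 2 and R in compound 3. Among the compounds with values here, no measured pair of stereoisomers exists, so the data give no direct size for such a change. No step beyond the scatter is expected, with a slight lean toward a lower number. The estimated 1.6-fold lower number from compound 2 to compound 3 (0.20 log units; within the scatter) reflects that lean. For compound 3 the expected value is 20000 nM with an estimated range from 7000 nM to 60000 nM in this measurement.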

Compound 3, half-maximal inhibitory concentration: 168000 nM
Compound 3: the middle estimate sits 8.4-fold (0.92 log units) below what was measured, and the stated range ends below it.
By their numbers in this assay, from the lowest: compound 1; then compound 2; then compound 3.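

In this assay the configuration at this saturated ring carbon now shows a measured effect, with a 5.3-fold higher number from compound 2 to compound 3 (0.73 log units; beyond the scatter), and within this pair the form drawn S holds the lower number. That step reflects configuration alone: the fact that compounds 2 and 3 differ only in the configuration as drawn. The series also now holds a single-place comparison of cyano in place of methoxy on an aromatic carbon, with a 24-fold higher number from compound 1 to compound 3 (1.39 log units; beyond the scatter).

Going by these compounds alone, still open is whether the same inversion gives a step of similar size when methoxy stands in place of cyano, as this series shows only one pair of stereoisomers. Also open, as far as these compounds go, is where an amine or a carboxylic acid in place of cyano on that aromatic carbon would fall relative to the methoxy and cyano compounds.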